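The compounds below may be only part of what the source reports. "The series", "measured", "known", "first", "only" and "open" are said of these compounds alone.

Among the compounds with values here, compound 3 `CCCCC/C=C\C/C=C\C/C=C\C=C\C(CCCC(=O)O)CC(=O)O` carries the highest number of the three compounds measured so far in an assay for inhibition of Polyunsaturated fatty acid 5-lipoxygenase (Rattus norvegicus); a lower number here means a stronger inhibitor, a higher number a weaker inhibitor: compound 3 gives 96000 nM. Compound 1 `CCCCC/C=C\C/C=C\C/C=C\C=C\C(S)CCCC(=O)O` gives 7600 nM and compound 2 `CCCCC/C=C\C/C=C\C/C=C\C=C\C(CCCC(=O)O)CC(=O)NO` gives 190 nM. All three steps between them lie beyond the scatter: a 13-fold higher number from compound 1 to compound 3 (1.10 log units; beyond the scatter), a 40-fold lower number from compound 1 to compound 2 (1.60 log units; beyond the scatter) and a 510-fold higher number from compound 2 to compound 3 (2.70 log units; beyond the scatter).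

Compound 4 `CCCCC/C=C\C/C=C\C/C=C\C=C\C(N)CCCC(=O)O` differs from compound 3 in one place: amino in place of carboxymethyl on a saturated chain carbon bound to a double-bonded chain carbon and a saturated chain carbon. Within the data shown here, no measured step introduces an amino group, so the bearing of the measured steps is indirect. The step of a 13-fold higher number from compound 1 to compound 3 (1.10 log units; beyond the scatter) shows that the carboxymethyl group at this position gives a far higher number than the sulfanyl group, and amino is, like sulfanyl, a small group of the kind counted above. The step of a 40-fold lower number from compound 1 to compound 2 (1.60 log units; beyond the scatter) concerns a hydroxycarbamoylmethyl group and does not speak directly to an amino group. Among the measured compounds shown here, the expectation for compound 4 is therefore a large fall in this assay relative to compound 3, bringing the number back toward that of compound 1, with wide uncertainty given that no amino analogue has been measured. The expected step is a 12-fold lower number from compound 3 to compound 4 (1.08 log units; beyond the scatter). For compound 4 the estimated value in this assay is 8000 nM, within a range from 1500 nM to 45000 nM.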

Compound 4, half-maximal inhibitory concentration: 25000 nM
Estimate against measurement, compound 4: 3.1-fold (0.49 log units) below, within the range that was stated.
By their numbers in this assay, from the lowest: compound 2; then compound 1; then compound 4; then compound 3.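

In this assay, amino on a saturated chain carbon bound to a double-bonded chain carbon and a saturated chain carbon gives a number that lies apart from both earlier groups at this position, with a modest step from carboxymethyl (a 3.8-fold lower number from compound 3 to compound 4 (0.58 log units; beyond the scatter)) and a modest step from sulfanyl (a 3.3-fold higher number from compound 1 to compound 4 (0.52 log units; beyond the scatter)), so the order of these three groups is now resolved beyond the scatter. Compound 4 also shows that exchanging the four heavy atoms of carboxymethyl for the one heavy atom of amino recovers only part of the large gap between compound 3 and compound 1, while the (hydroxycarbamoyl)methyl group of compound 2 stays far ahead of amino (a 130-fold higher number from compound 2 to compound 4 (2.12 log units; beyond the scatter)). Nothing available explains this order of the numbers.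

The compounds shown leave open how a hydroxy group or a methylamino group at this position would compare with amino and sulfanyl. They also leave open whether an aminomethyl group, with the amine set on a longer chain, would move the number toward that of compound 2, and whether a hydroxycarbamoyl group bound directly to this carbon would hold that low number.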